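Removing the ring chloro from compound 1

The source may hold more compounds than are shown below. What is called first, only, known or untested is meant among the compounds shown, and "the series" means these compounds.

Compound 1 `Cn1nc(-c2ccc(Cl)cc2)n(C)c1=S` gives 1.34 mg/kg in a functional assay on the whole organism with Mus musculus as the target (a lower number here means that less compound is needed, a higher number that more compound is needed for the effect), the lowest of the two numbers recorded for the series. Compound 2 `Cn1nc(-c2ccc(Cl)c(Cl)c2)n(C)c1=S`, carrying an additional chloro on an aromatic carbon, gives 29 mg/kg in this assay. Compound 3 `Cn1nc(-c2ccc(Cl)cc2Cl)n(C)c1=S` reaches only a limit in this assay, > 25 mg/kg (the limit of > 25 mg/kg in this assay, at which 1 of the 3 values shown sits). The two measured steps, a 22-fold higher number from compound 1 to compound 2 (1.34 log units; beyond the scatter) and an at least 18-fold higher number from compound 1 to compound 3 (1.27 log units; beyond the scatter), both show that adding a chloro to the aromatic ring of compound 1 pushes the dose sharply upward.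

Compound 4 `Cn1nc(-c2ccccc2)n(C)c1=S` is the unmeasured member: hydrogen in place of chloro on an aromatic carbon. This change removes the chloro present in compound 1 rather than adding one, so neither measured step tracks it directly; together they only show that the dose responds strongly to the halogen pattern on this ring, in the direction of needing more compound when the pattern is altered. Compound 4 is therefore expected to need a moderately higher dose, a step of a 2.6-fold higher number from compound 1 to compound 4 (0.42 log units; beyond the scatter). The estimate for compound 4 in this assay is 3.5 mg/kg, within 0.8 mg/kg to 15 mg/kg.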

Compound 4, dose for half-maximal effect: 0.15 mg/kg
Beside the measured number, compound 4's estimate is 23-fold (1.37 log units) above it, and the stated range ends above it.
By their numbers in this assay, from the lowest: compound 4; then compound 1; then compound 2.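

In this assay, the step from chloro to hydrogen on the aromatic carbon para to a group of 8 heavy atoms gives an 8.9-fold lower number from compound 1 to compound 4 (0.95 log units; beyond the scatter), so the chloro of compound 1 is not needed for the effect at this place. The earlier steps shown here only added a second chloro to the ring and could not show this. Neither of them changed this position. Within the data shown here, all three steps from compound 1 now agree, with no compound against them: a second ring chloro raises the number, and removing the single chloro lowers it.

Whether fluoro, methoxy or an amine at this place would keep the lower number stays open, and nothing at hand bears on why hydrogen gives this step. On these data alone, compound 3 stands only as a limit, so its true position also stays open: the limit of > 25 mg/kg in this assay, at which 1 of the 4 values shown sits.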